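This account rests on a few compounds, and the source may have more. Where it says the series, first, only, none or still open, it means among the compounds named here.

In a functional assay on HL-60 cells (Homo sapiens) for inhibition, read by CCK-8 assay, with a stated time of 48 h (on this read-out higher numbers stand for weaker inhibition and lower numbers for stronger inhibition), compound 1 (`COc1ccc(S(=O)(=O)Oc2ccccc2/C=C(\C#N)C(=O)Nc2nnc(-c3cccs3)s2)cc1`) gives 5230 nM and compound 2 (`Cc1ccc(S(=O)(=O)Oc2cccc(/C=C(\C#N)C(=O)Nc3nnc(-c4cccs4)s3)c2)cc1`) gives 8750 nM. These two numbers lie within the usual scatter of repeated measurements, so compound 1 stands level with compound 2 and the two cannot be ranked. The pair also differs in more than one place, so it shows no clean effect of any single structural change.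

Compound 3 (`COc1ccc(S(=O)(=O)Oc2ccccc2/C=C(\C#N)C(=O)Nc2nnc(Cc3cccc(F)c3)s2)cc1`) keeps the rest of compound 1 but carries 3-fluorobenzyl in place of thiophen-2-yl on an aromatic carbon. Both measured compounds carry thiophen-2-yl at this place, so the data offer no direct guide to this swap. Among the measured compounds shown here, the only anchor is the value of compound 1, 5230 nM, and a wide range is needed around it. With no evidence for a direction, no change beyond the scatter is expected in this assay, and the estimated step is a 1.2-fold lower number from compound 1 to compound 3 (0.07 log units; within the scatter). The expected value for compound 3 is 4500 nM, with an estimated range from 1500 nM to 14000 nM.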

Compound 3, half-maximal inhibitory concentration: 3880 nM
The estimate for compound 3 lay 1.2-fold (0.06 log units) above the measured number, and the stated range covers the measured number.
By their numbers in this assay, from the lowest: compounds 3, 1 and 2 (each within the scatter of the next, the first and the last beyond it).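

In this assay, replacing thiophen-2-yl with 3-fluorobenzyl on the aromatic carbon of the five-membered ring with 2 nitrogen and 1 sulfur gives a 1.3-fold lower number from compound 1 to compound 3 (0.13 log units; within the scatter), so the two compounds stand level and cannot be ranked. Among the compounds shown here, this is the first change seen at this position, and it shows that a five-membered aromatic ring containing sulfur can give way to a larger benzyl group with a carbon-only six-membered ring, with no change beyond the scatter in this read-out. No measurement here explains why the number holds across this swap.

For the compounds shown here, the single swap leaves open whether plain benzyl, without the fluorine, or a quite different group at this place, such as an amine or a carboxylic acid, would also keep the number in this range. It also leaves open whether 3-fluorobenzyl would behave the same way on compound 2, which differs from compound 1 in more than one place.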